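The source may hold more compounds than are shown below. What is called first, only, known or untested is meant among the compounds shown, and "the series" means these compounds.

Measured in a functional assay on A-375 cells (Homo sapiens) for inhibition, read by CCK-8 assay, with a stated time of 72 h; a higher number here means a weaker inhibitor, a lower number a stronger inhibitor:
- compound 1 `Nc1ccccc1NC(=O)c1ccc(CNC(=O)c2n[nH]cc2NC(=O)c2ccccc2Cl)cc1`: 2110 nM
- compound 2 `O=C(NO)c1ccc(CNC(=O)c2n[nH]cc2NC(=O)c2ccccc2F)cc1`: 3010 nM

In this assay, compound 2 at 3010 nM lies within the usual scatter of compound 1 at 2110 nM, so these two numbers cannot be ranked. Compound 3 `O=C(NO)c1ccc(CNC(=O)c2n[nH]cc2NC(=O)c2ccccc2Cl)cc1` is compound 2 with chloro in place of fluoro on an aromatic carbon, ortho to a large group: chloro in place of fluoro on an aromatic carbon. Among the compounds with values here, no measured pair shows this swap on its own. The expected change is none beyond the scatter, an estimated 1.2-fold lower number from compound 2 to compound 3 (0.08 log units; within the scatter). The estimate for compound 3 is 2500 nM, with an expected range of 1000 nM to 6000 nM.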

Compound 3, half-maximal inhibitory concentration: 6420 nM
The estimate for compound 3 lay 2.6-fold (0.41 log units) below the measured number; the whole stated range lies below it.
By their numbers in this assay, from the lowest: compounds 1 and 2 (each within the scatter of the next); then compound 3.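

In this assay the change from 2-fluorophenyl to 2-chlorophenyl gives a 2.1-fold higher number from compound 2 to compound 3 (0.33 log units; beyond the scatter) and so shows that this aromatic carbon, ortho to a large group, is sensitive to which halogen it carries. With the chloro group held fixed, hydroxy in place of 2-aminophenyl on an amide-type nitrogen gives a 3.0-fold higher number from compound 1 to compound 3 (0.48 log units; beyond the scatter) and so shows that this other end of the molecule also affects the number. Still open, going by these compounds, is how a bromo, methyl or methoxy group would read at the same carbon. No measurement shown gives a reason for either step.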